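Ring-size swap on the amine of the quinazoline-like core

A few compounds are considered here, and "the series" means these few. Any claim that something is new, unique, unknown or untested is made for them only; others in the source may bear on it.

Measured so far:
- compound 1, `CCC/C=C/C(=O)Nc1cc2c(N3CCCc4ccccc43)ncnc2cc1OC`: 1800 nM
- compound 2, `COc1cc2ncnc(N3CCc4ccccc43)c2cc1NC(=O)/C=C/CN1CCCCC1`: 2540 nM

Both numbers come from a functional assay on A549 cells (Homo sapiens) for antiproliferative activity, read by MTT assay, with a stated time of 72 h; on this read-out lower numbers stand for stronger inhibition and higher numbers for weaker inhibition. In this assay compound 2 gives 2540 nM, the highest of the two numbers; its nearest neighbour is compound 1 with 1800 nM, and the gap between them sits within the usual scatter, so no order can be read from it.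

Compound 3, `COc1cc2ncnc(N3CCCc4ccccc43)c2cc1NC(=O)/C=C/CN1CCCCC1`, is not yet measured. It differs from compound 2 in one place: 1,2,3,4-tetrahydroquinolin-1-yl in place of 2,3-dihydro-1H-indol-1-yl on an aromatic carbon. The amide side of compound 3 is that of compound 2, while its amine matches compound 1. Going by the values given here, no step between measured compounds that differ in only one place exists in this set, so the change has no measured precedent here.

Expectation: the step is expected to be small, with no direction beyond the scatter, because compound 1 gives 1800 nM with the same amine. Compound 3 is therefore expected to give 2000 nM, in the range 800 nM to 5000 nM, an expected step of a 1.3-fold lower number from compound 2 to compound 3 (0.10 log units; within the scatter).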

Compound 3, half-maximal inhibitory concentration: 2880 nM
Compound 3: the middle estimate sits 1.4-fold (0.16 log units) below what was measured; the measured number falls inside the stated range.
By their numbers in this assay, from the lowest: compounds 1, 2 and 3 (each within the scatter of the next).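

In this assay, 1,2,3,4-tetrahydroquinolin-1-yl in place of 2,3-dihydro-1H-indol-1-yl on the aromatic carbon gives a step within the scatter (a 1.1-fold higher number from compound 2 to compound 3 (0.05 log units; within the scatter)), so with the piperidin-1-yl side chain held fixed, this ring-size swap does not separate the two compounds. With 1,2,3,4-tetrahydroquinolin-1-yl held fixed, piperidin-1-yl in place of ethyl on the saturated chain carbon also stays within the scatter (a 1.6-fold higher number from compound 1 to compound 3 (0.20 log units; within the scatter)). Nothing available bears on why both steps stay this small.

Open, as far as these compounds go, is whether any change at either place can move the number beyond the scatter. A morpholin-4-yl group on the saturated chain carbon, or an open-chain methylanilino group on the aromatic carbon, would test this.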